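The source may hold more compounds than are shown below. What is called first, only, known or untested is meant among the compounds shown, and "the series" means these compounds.

Measured compounds and their numbers in one cytotoxicity read-out:

Compound 1 `CC(C)c1ccc(-n2nc(-c3ccc(C(F)(F)F)cc3O)nc2-c2ccccc2O)cc1`: 100%
Compound 2 `Oc1cc(C(F)(F)F)ccc1-c1nc(-c2ccccc2O)n(-c2ccc(I)cc2)n1`: 94.4%
Compound 3 `COc1cccc(-n2nc(-c3ccc(C(F)(F)F)cc3O)nc2-c2ccccc2O)c1`: 96.8%

All three share one core and were tested in a functional assay on PC-12 cells (Rattus norvegicus) for cytotoxicity, read by MTT assay, with stated times of 2 h and 24 h, tested at 5 uM; a higher number here means a stronger effect of the compound at the concentration tested, a lower number a weaker effect. In this assay compound 1 gives 100%, and the other two numbers sit close to it: a number 3.2 percentage points lower from compound 1 to compound 3 (within the scatter), and a number 5.6 percentage points lower from compound 1 to compound 2 (within the scatter). The third pairing is of the same kind: a number 2.4 percentage points higher from compound 2 to compound 3 (within the scatter). Every replacement on the aromatic nitrogen of the core, whether 3-methoxyphenyl for 4-isopropylphenyl or 3-methoxyphenyl for 4-iodophenyl, has so far left the number where it was, within the scatter.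

Compound 4 `Cc1cc(C)cc(-n2nc(-c3ccc(C(F)(F)F)cc3O)nc2-c2ccccc2O)c1` is not yet measured. It differs from compound 1 in one place: 3,5-dimethylphenyl in place of 4-isopropylphenyl on an aromatic nitrogen. This is again a change of the group on the aromatic nitrogen, the same place that was altered from compound 1 to compound 3 and from compound 2 to compound 3, and neither of those steps moved the read-out beyond the scatter. The same is therefore expected here: a step of no real size, in no particular direction, that is a number 3 percentage points lower from compound 1 to compound 4 (within the scatter).

For compound 4 in this assay the expected value is 97%, with a likely range from 88% to 100%.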

Compound 4, a percentage reported as activity, at one concentration (the size of the read-out at that concentration, not a potency): 102%
Estimate against measurement, compound 4: 5 percentage points below; the whole stated range lies below it.
By their numbers in this assay, from the lowest: compounds 2, 3, 1 and 4 (each within the scatter of the next).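

In this assay, placing 3,5-dimethylphenyl on the aromatic nitrogen instead of 4-isopropylphenyl gives a number 2 percentage points higher from compound 1 to compound 4 (within the scatter), so moving from one para-free pattern of small carbon groups to another is not the point: a ring with two methyl groups simply joins the others at this position. Against the remaining two compounds the picture holds, with a number 5.2 percentage points higher from compound 3 to compound 4 (within the scatter) and a number 7.6 percentage points higher from compound 2 to compound 4 (within the scatter), and even this last step, the widest in the set, does not separate the two compounds, so the four aromatic groups tried on this nitrogen cannot be told apart in this read-out at the one concentration tested. Nothing available here explains why these groups give such similar numbers.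

Going by these compounds, all four compounds carry a substituted phenyl ring on this nitrogen, so it remains open whether a phenyl ring bearing an amine or a carboxylic acid, or a longer chain in place of the ring, would shift the number. The compounds also share the 2-hydroxyphenyl group and the trifluoromethyl-bearing ring, which leaves the effect of changes at those parts of the shared core open too.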